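Expected effect of a chloro group on compound 2

The source may hold more compounds than are shown below. What is called first, only, known or untested is meant among the compounds shown, and "the series" means these compounds.

Compound 1 `Cc1cnc(Oc2cc(Cl)c(F)c(-c3ccc4c(c3)CC[C@H](CCC(=O)O)O4)c2)s1`: in a functional assay on HEK293 cells for agonist activity at Free fatty acid receptor 1 (Homo sapiens), read by HTRF and inositol phosphate accumulation, with a stated time of 60 min (a lower number here means that less compound is needed, a higher number that more compound is needed for the effect), compound 1 reaches only the assay limit, > 10000 nM, and gives no number.
Compound 2 `O=C(O)CC[C@H]1CCc2cc(-c3cc(OC4CCC4)ccc3F)ccc2O1`: in this assay compound 2 gives 3600 nM.
Compound 3 `O=C(O)CC[C@H]1CCc2cc(-c3cc(OC(F)(F)F)ccc3F)ccc2O1`: in this assay compound 3 gives 2100 nM.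

Compound 2 thus holds the highest of the two numbers measured; its nearest neighbour is compound 3, and the change a 1.7-fold lower number from compound 2 to compound 3 (0.23 log units; within the scatter) stays within the scatter, so the two cannot be ranked against each other. Compound 1 stands apart as a limit (the limit of > 10000 nM in this assay, at which 1 of the 3 values shown sits).

Compound 4 `O=C(O)CC[C@H]1CCc2cc(-c3cc(OC4CCC4)cc(Cl)c3F)ccc2O1` has not been measured. It differs from compound 2 in a single place: chloro in place of hydrogen on an aromatic carbon. Going by the values given here, no measured step puts a chloro group in exactly this way, so the expectation leans on what the values show. Compound 1, which also carries a chloro group and a fluoro group on the same ring, gave only a limit, but it differs from compound 4 in more than one place, so it serves as a caution rather than a guide. The step of a 1.7-fold lower number from compound 2 to compound 3 (0.23 log units; within the scatter), swapping the group on the ring oxygen, changed little.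

Compound 4 is therefore expected to sit near compound 2, with a step of a 1.5-fold higher number from compound 2 to compound 4 (0.18 log units; within the scatter) that may lean towards a higher number. The estimate for compound 4 is 5500 nM, within 1800 nM to 16000 nM.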

Compound 4, half-maximal effective concentration: > 10000 nM
Compound 4: no number, only a limit (the forecaster's own chance of this, stated with the estimate: 30%); middle value at least 1.8-fold (0.25 log units) from the limit.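

Adding one chloro group to this aromatic carbon, ortho to a fluoro group, gives an at least 2.7-fold higher number from compound 2 to compound 4 (0.44 log units; beyond the scatter), whereas changing the group on the ring oxygen gave only a 1.7-fold lower number from compound 2 to compound 3 (0.23 log units; within the scatter). This makes the aromatic carbon the first place in this small set where a single change moves the result beyond the scatter, and the direction is towards needing more compound. Compound 1 also carries a chloro group ortho to a fluoro group, but the step from compound 1 to compound 4 cannot be read, since neither compound gives a number: the limit of > 10000 nM in this assay, at which 2 of the 4 values shown sit.

On these data alone, it remains open whether a different group on this aromatic carbon, such as a methyl, a methoxy or a second fluoro group, would keep the number close to that of compound 2 in this assay. As far as these compounds go, it is also open whether the chloro group would have a similar effect with trifluoromethyl on the oxygen, as in compound 3, rather than the cyclobutyl of compound 2.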